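This account rests on a few compounds, and the source may have more. Where it says the series, first, only, none or still open, it means among the compounds named here.

This account follows one step in a toxicity assay on HepG2 cells (Homo sapiens) for inhibition, read by CellTiter-Glo, with a stated time of 48 h; on this read-out lower numbers stand for stronger inhibition and higher numbers for weaker inhibition. Compound 1 `Cc1cc(C)cc(NC(=O)COc2cc(C)nc3ccc(OC(F)(F)F)cc23)c1` belongs to the same small set. In this assay compound 1 reaches only the limit of the assay, > 100000 nM, and no number. Compound 2 `COc1ccc(NC(=O)COc2cc(C)nc3ccc(OC)cc23)cc1` likewise gives in this assay only a limit, > 100000 nM, rather than a measured figure. Within the data shown here, compound 2 thus stands at the limit of > 100000 nM in this assay, at which 2 of the 2 values shown sit, and the one further value shown is the same limit. Among the measured compounds shown here, no step between measured compounds can be drawn from these two, so nothing about the size of a change is known from them. Compound 3 `COc1ccc2nc(C)cc(OCC(=O)NNC(=O)c3ccncc3)c2c1` is still to be measured in this assay. It differs from compound 2 by the change (((pyridin-4-yl)carbonyl)amino in place of 4-methoxyphenyl on an amide-type nitrogen). Since both measured compounds sit at the limit, the step from compound 2 to compound 3 is expected to be none beyond the scatter. The estimate for compound 3 is 100000 nM, with a range from 30000 nM to 300000 nM. This corresponds to an expected step of a number no higher from compound 2 to compound 3 (the limit leaves the size open).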

Compound 3, half-maximal inhibitory concentration: > 100000 nM
Compound 3: only a limit was reported (the forecaster's own chance of this, stated with the estimate: 75%); the middle value sits exactly at the limit.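

In this assay compound 3 gives only a limit, > 100000 nM, so no step can be read between compound 2 and compound 3: the limit of > 100000 nM in this assay, at which 3 of the 3 values shown sit. The compounds shown leave open whether ((pyridin-4-yl)carbonyl)amino in place of 4-methoxyphenyl changes the read-out at all.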